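The source may hold more compounds than are shown below. What is called first, only, known or untested is meant among the compounds shown, and "the series" means these compounds.

Measured compounds:
compound 1 `CN(C)c1ncnc2c1c(-c1cc3ccccc3o1)cn2[C@@H]1O[C@H](CO)[C@@H](O)[C@H]1O`, > 100000 nM
compound 2 `C#Cc1cn([C@@H]2O[C@H](CO)[C@@H](O)[C@H]2O)c2ncnc(N(C)C)c12`, 36100 nM

In an ADME assay on MRC5 cells (Homo sapiens), read by MTT assay, with a stated time of 72 h (on this read-out higher numbers stand for weaker inhibition and lower numbers for stronger inhibition), compound 1 gives only a limit, > 100000 nM, and no number. That is the limit of > 100000 nM in this assay, at which 1 of the 2 values shown sits. In this assay compound 2 gives 36100 nM. Going by the values given here, the single measured step, an at least 2.7-fold lower number from compound 1 to compound 2 (0.44 log units; beyond the scatter), concerns a different place from the change that leads to compound 3 `CNc1ncnc2c1c(-c1cc3ccccc3o1)cn2[C@@H]1O[C@H](CO)[C@@H](O)[C@H]1O`, namely (hydrogen in place of methyl on a nitrogen on an aromatic ring). Among the compounds with values here, no measured step bears on this change, so no shift beyond the scatter is expected from it. Compound 3 is therefore expected to stay near the same limit, a step that the limit leaves unreadable from compound 1 to compound 3, estimated at 150000 nM with a range from 60000 nM to 400000 nM.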

Compound 3, half-maximal inhibitory concentration: 75300 nM
Beside the measured number, compound 3's estimate is 2.0-fold (0.30 log units) above it; measured number inside the range.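

In this assay, compound 3, which carries methylamino in place of dimethylamino, gives a number, 75300 nM, on the core with 1-benzofuran-2-yl. The step, an at least 1.3-fold lower number from compound 1 to compound 3 (0.12 log units; that floor lies within the scatter), has a floor that does not clear the scatter, so a real drop from this change on the nitrogen is neither shown nor excluded. Compound 1 gives only a limit, and because of this the true size of the step stays unread: the limit of > 100000 nM in this assay, at which 1 of the 3 values shown sits.

Going by these compounds, what a longer chain such as ethyl on this nitrogen, or an unsubstituted amine, would give stays open. So does whether the same change reads alike with ethynyl on the core.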